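Notes on compound 4: methyl to benzyl

The source may hold more compounds than are shown below. What is called first, only, known or untested is meant among the compounds shown, and "the series" means these compounds.

Compound 1 `O=C(O[C@H]1C[C@H](n2cc(F)c(=O)[nH]c2=O)O[C@@H]1COP(=O)(O)Oc1ccccc1)c1ccccc1` is the reference of the set; in a physicochemical assay for metabolic stability, read by HPLC, tested at 2 mM (on this read-out higher numbers stand for a longer-lived compound and lower numbers for a shorter-lived compound), compound 1 gives 6.6 h. Compound 2 `O=C(O[C@H]1C[C@H](n2cc(F)c(=O)[nH]c2=O)O[C@@H]1COP(=O)(O)Oc1cccnc1)c1ccccc1` gives 6.7 h, and the step of a 1.0-fold higher number from compound 1 to compound 2 (0.01 log units; within the scatter) sits within the scatter. Compound 3 `C[n+]1cccc(OP(=O)([O-])OC[C@H]2O[C@@H](n3cc(F)c(=O)[nH]c3=O)C[C@@H]2OC(=O)c2ccccc2)c1` gives 14.8 h, the highest of the three numbers; the steps of a 2.2-fold higher number from compound 1 to compound 3 (0.35 log units; beyond the scatter) and a 2.2-fold higher number from compound 2 to compound 3 (0.34 log units; beyond the scatter) are modest but beyond the scatter.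

Compound 4 `O=C(O[C@H]1C[C@H](n2cc(F)c(=O)[nH]c2=O)O[C@@H]1COP(=O)([O-])Oc1ccc[n+](Cc2ccccc2)c1)c1ccccc1` differs from compound 3 by phenyl in place of hydrogen on a saturated chain carbon bound to an aromatic nitrogen. Among the compounds with values here, no measured pair alters this saturated chain carbon. Within the data shown here, the two steps beyond the scatter both concern the larger group on the oxygen on a saturated carbon, and the only change confined to an aromatic ring, a 1.0-fold higher number from compound 1 to compound 2 (0.01 log units; within the scatter), stayed within the scatter. There is thus no measured basis for a step beyond the scatter from compound 3 to compound 4, and none is expected. Compound 4 is expected to give about 14 h, with a range of 7 h to 28 h. The step of a 1.1-fold lower number from compound 3 to compound 4 (0.02 log units; within the scatter) is expected to remain within the scatter.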

Compound 4, half-life: 10.8 h
Beside the measured number, compound 4's estimate is 1.3-fold (0.11 log units) above it, and the stated range covers the measured number.
By their numbers in this assay, from the lowest: compounds 1, 2, 4 and 3 (each within the scatter of the next, the first and the last beyond it).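

Compound 3 and compound 4 form the only pair shown that alters the saturated chain carbon bound to an aromatic nitrogen, and a 1.4-fold lower number from compound 3 to compound 4 (0.14 log units; within the scatter) is the outcome of going from methyl to benzyl in this assay. At this position, phenyl in place of hydrogen gives no step beyond the scatter on this read-out. No measurement shown bears on what lies behind this result.

On these data alone, whether an amine, a carboxylic acid or a longer chain in place of the phenyl at this saturated chain carbon would also stay within the scatter remains open. A single pair also leaves open whether methyl to benzyl would read the same with any other group on the shared core.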